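The source may report more compounds than this note shows. Statements on the series, on what has been measured and on what is new or still open speak of the compounds shown alone.

Compound 1 `CCc1csc(CN[C@@H]2C[C@H]3C[C@@H]([C@H]2C)C3(C)C)c1`: 25000 nM
Compound 2 `C[C@H]1[C@H](NCc2cncnc2)C[C@H]2C[C@@H]1C2(C)C`: > 100000 nM
Compound 3 `CCOc1ccsc1CN[C@@H]1C[C@H]2C[C@@H]([C@H]1C)C2(C)C`: 50000 nM

Three amines built on the same saturated bicyclic core have been tested in an ADME assay on MDCK cells (Canis lupus familiaris) for cytotoxicity, read by microscopy, with a stated time of 48 h; on this read-out lower numbers stand for higher toxicity in this test and higher numbers for lower toxicity in this test. Compound 1 gives 25000 nM in this assay, and compound 3 gives 50000 nM. For compound 2 the test returned only a limit, > 100000 nM, so no number is known for it; this is the situation described by the limit of > 100000 nM in this assay, at which 1 of the 3 values shown sits. Compound 2 is therefore the only one of the three without a measured number, while compound 1 and compound 3, each carrying a five-membered sulfur-containing ring, both give values inside the measured range.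

Compound 4 `C[C@H]1[C@H](NCc2cncs2)C[C@H]2C[C@@H]1C2(C)C` has not yet been measured. It differs from compound 2 in a single place: 1,3-thiazol-5-yl in place of pyrimidin-5-yl on a saturated chain carbon bound to an amine nitrogen. For the measured compounds named here, no measured pair of compounds shows this change directly. Compound 4 is expected to give a number rather than a limit, with a step of an at least 2.0-fold lower number from compound 2 to compound 4 (0.30 log units; that floor lies within the scatter) toward higher toxicity. Compound 4 is estimated at 50000 nM, with a range from 20000 nM to 100000 nM.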

Compound 4, minimum cytotoxic concentration: > 100000 nM
Compound 4 ended at the assay's limit; the forecaster's own chance of this, stated with the estimate: 35%; at least 2.0-fold (0.30 log units) between middle value and limit.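

Compound 4, like compound 2, returned only a limit in this assay, so the step between them cannot be read: the limit of > 100000 nM in this assay, at which 2 of the 4 values shown sit.

The compounds shown leave open whether 1,3-thiazol-5-yl in place of pyrimidin-5-yl changes the read-out in this assay at all, and in which direction.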